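A few compounds are considered here, and "the series" means these few. Any claim that something is new, unique, unknown or untested is made for them only; others in the source may bear on it.

Measured in a functional assay on HCT-116 cells (Homo sapiens) for cytotoxicity; on this read-out lower numbers stand for stronger inhibition and higher numbers for weaker inhibition:
Compound 1 (`CCCCCCC[C@@H]1CC(=O)N[C@H](CC(C)C)C(=O)N[C@@H](CO)C(=O)N[C@@H]([C@@H](C)O)C(=O)N[C@H](CC(C)C)C(=O)N[C@@H]([C@@H](C)CC)C(=O)O1`): "not determined" (no result reported)
Compound 2 (`CC[C@H](C)[C@@H]1NC(=O)[C@@H](CC(C)C)NC(=O)[C@H]([C@@H](C)O)NC(=O)[C@H](CO)NC(=O)[C@@H](CC(C)C)NC(=O)C[C@@H](CCCCCCC(C)C)OC1=O`): 50000 nM

Within the data shown here, only one number is available so far. Compound 2 gives 50000 nM in this assay, and with no result for compound 1, there is nothing to rank it against. Whether this value is high or low within the series cannot yet be said.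

The next compound to be tested is compound 3 (`CCCCCCCCCCC[C@@H]1CC(=O)N[C@H](CC(C)C)C(=O)N[C@@H](CO)C(=O)N[C@@H]([C@@H](C)O)C(=O)N[C@H](CC(C)C)C(=O)N[C@@H]([C@@H](C)CC)C(=O)O1`). Its structure differs from that of compound 2 by one change, (pentyl in place of isopropyl on a saturated chain carbon, six bonds along the chain from a saturated ring carbon), which puts pentyl in place of isopropyl on a saturated chain carbon, six bonds along the chain from a saturated ring carbon.

Among the measured compounds shown here, no pair of measured compounds shows what a change of this kind does, so the expectation rests on compound 2 at 50000 nM alone. The expected result in this assay is no step beyond the usual scatter, and no firm direction can be given. The estimate means an expected move a 1.4-fold lower number from compound 2 to compound 3 (0.15 log units; within the scatter), which is small. For compound 3 the estimated value is 35000 nM, with an expected range from 12000 nM to 90000 nM.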

Compound 3, half-maximal inhibitory concentration: 18000 nM
Compound 3: middle estimate off by 1.9-fold (0.29 log units), on the high side; the measured number falls inside the stated range.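

In this assay, among these compounds, the first comparison shows that the read-out responds to a change at this place: pentyl in place of isopropyl, on a saturated chain carbon, six bonds along the chain from a saturated ring carbon, gives a 2.8-fold lower number from compound 2 to compound 3 (0.44 log units; beyond the scatter). The step is modest, but it lies beyond the usual scatter and points towards stronger inhibition, so this place on the chain can affect the result. The change replaces a branched group of 3 carbons with an unbranched group of 5 carbons, neither carrying a hydrogen-bond donor or acceptor, and no available evidence explains the shift.

Length and branching change together in this single step, so it remains open which of them matters; unbranched propyl or a branched group of 5 carbons at the same place would help to separate the two. Also open, from the compounds shown here alone, is whether the number keeps falling with a longer chain such as decyl, and what an amine or a carboxylic acid would do at this place.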